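Removing a Methyl From a Weak Sulfonamide Inhibitor

The source may hold more compounds than are shown below. What is called first, only, known or untested is meant among the compounds shown, and "the series" means these compounds.

Measured compounds:
Compound 1 `CCC(C)C(C(=O)Nc1ccc(C(C)=O)cc1)N(C(=O)c1ccccc1)S(=O)(=O)c1ccc([N+](=O)[O-])cc1` gives 48.4%.
Compound 2 `CC(=O)c1ccc(NC(=O)C(C(C)C)N(C(=O)c2ccccc2)S(=O)(=O)c2ccc([N+](=O)[O-])cc2)cc1` gives 27.2%.
Compound 3 `CCC(C)C(C(=O)Nc1ccc(C(C)=O)cc1)N(C(=O)c1ccccc1)S(=O)(=O)c1ccccc1` gives 15.5%.

The three measured compounds were tested in a functional assay for inhibition, read by spectrophotometry, with a stated time of 20 min, tested at 4 mg/mL; a higher number here means a stronger effect of the compound at the concentration tested, a lower number a weaker effect. Compound 1 stands highest, and the step of a number 32.9 percentage points lower from compound 1 to compound 3 (beyond the scatter) corresponds to the change (hydrogen in place of nitro on an aromatic carbon), which is also how the core of compound 3 differs from that of compound 1. Within the core of compound 1, the change hydrogen in place of methyl on a saturated chain carbon, three bonds along the chain from an amide-type nitrogen and a carbonyl carbon gave the step of a number 21.2 percentage points lower from compound 1 to compound 2 (beyond the scatter).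

Compound 4 `CC(=O)c1ccc(NC(=O)C(C(C)C)N(C(=O)c2ccccc2)S(=O)(=O)c2ccccc2)cc1` carries the same change, (hydrogen in place of methyl on a saturated chain carbon, three bonds along the chain from an amide-type nitrogen and a carbonyl carbon), but on the core of compound 3. Since compound 3 already gives 15.5%, a step as large as that from compound 1 to compound 2 cannot fully appear; the read-out is expected to fall to near zero, so the step of a number 10.5 percentage points lower from compound 3 to compound 4 (beyond the scatter) is estimated to be smaller. Compound 4 is therefore expected to give about 5%, between 0% and 18%.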

Compound 4, a percentage reported as inhibition, at one concentration (the size of the read-out at that concentration, not a potency): 52.2%
Beside the measured number, compound 4's estimate is 47.2 percentage points below it; measured number outside the range, above it.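

In this assay, sec-butyl to isopropyl gave a number 36.7 percentage points higher from compound 3 to compound 4 (beyond the scatter), so on the core without the nitro the change reversed direction: the same change on two cores in this assay, a number 21.2 percentage points lower (beyond the scatter) from compound 1 to compound 2 and a number 36.7 percentage points higher (beyond the scatter) from compound 3 to compound 4, 57.9 percentage points apart, beyond the scatter of two such steps. Hydrogen in place of nitro, carried to the core with isopropyl, likewise gave a number 25 percentage points higher from compound 2 to compound 4 (beyond the scatter): the same change on two cores in this assay, a number 32.9 percentage points lower (beyond the scatter) from compound 1 to compound 3 and a number 25 percentage points higher (beyond the scatter) from compound 2 to compound 4, 57.9 percentage points apart, beyond the scatter of two such steps. In these four compounds the outcome of each change therefore depends on the other, but they do not show why this is so, nor whether it holds for other cores in the series.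

From the compounds shown here alone, whether the reversal persists with an ethyl or a longer chain in place of the sec-butyl remains open. So does the outcome with an amine or a carboxylic acid in place of the nitro.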